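The source may hold more compounds than are shown below. What is called first, only, known or untested is meant among the compounds shown, and "the series" means these compounds.

Measured compounds in an assay on CHO cells for antagonist activity at transient receptor potential cation channel subfamily V member 1 (Homo sapiens), read by FLIPR and calcium flux; on this read-out higher numbers stand for weaker inhibition and lower numbers for stronger inhibition:
- compound 1, `CC(C(=O)NCc1ccc(C(F)(F)F)nc1Cl)c1ccc(NS(C)(=O)=O)c(F)c1`: 0.2 nM
- compound 2, `CCCCCCc1nc(C(F)(F)F)ccc1CNC(=O)C(C)c1ccc(NS(C)(=O)=O)c(F)c1`: 1.6 nM
- compound 3, `C[C@H](C(=O)NCc1ccc(C(F)(F)F)nc1C1CC2CCC1C2)c1ccc(NS(C)(=O)=O)c(F)c1`: 0.8 nM

Compound 3 stands second highest of the three numbers in this assay. Its nearest neighbour is compound 2, which gives 1.6 nM, a gap within the scatter; the furthest is compound 1 with 0.2 nM, a gap beyond the scatter. Going by the values given here, the only single-point step among the measured compounds, an 8.0-fold higher number from compound 1 to compound 2 (0.90 log units; beyond the scatter), swaps hexyl in place of chloro on an aromatic carbon and does not touch the stereocentre.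

Compound 4, `CC(C(=O)NCc1ccc(C(F)(F)F)nc1C1CC2CCC1C2)c1ccc(NS(C)(=O)=O)c(F)c1`, differs from compound 3 only in this: the two compounds have the same atoms and bonds; at least one stereo element is drawn with a configuration in one of them and without one in the other: 1 of 4 stereo elements differ; a stereocentre at a saturated chain carbon is drawn S in compound 3 and without a configuration in compound 4. Compound 4 is thus the material without a drawn configuration at the chain carbon, where compound 3 carries the S configuration. Among the compounds with values here, no measured step bears directly on such a change; compounds 1 and 2 are likewise drawn without configuration and sit close to compound 3. If the S form is the more active component, the undrawn material is expected to give a somewhat higher number than compound 3, but the step of a 1.5-fold higher number from compound 3 to compound 4 (0.18 log units; within the scatter) is expected to stay within the scatter. Compound 4 is therefore estimated at 1.2 nM, in the range 0.5 nM to 3 nM.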

Compound 4, inhibition constant: 1.5 nM
Beside the measured number, compound 4's estimate is 1.3-fold (0.10 log units) below it; the range from low to high includes it.
By their numbers in this assay, from the lowest: compound 1; then compounds 3, 4 and 2 (each within the scatter of the next).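

In this assay, going by these compounds alone, the first comparison at the chain carbon gives a 1.9-fold higher number from compound 3 to compound 4 (0.27 log units; within the scatter), so the drawn S form and the material without a drawn configuration are not separated. At the aromatic carbon, the group with 2 five-membered non-aromatic rings of carbon only and hexyl are likewise not separated, with a 1.1-fold lower number from compound 2 to compound 4 (0.03 log units; within the scatter), whereas the same ring group in place of chlorine gives a 7.5-fold higher number from compound 1 to compound 4 (0.88 log units; beyond the scatter), which matches the size of the earlier hexyl-for-chloro step, an 8.0-fold higher number from compound 1 to compound 2 (0.90 log units; beyond the scatter). The stereo step remains a comparison of a defined form with undefined material, because of this difference in drawing: the fact that one of compounds 3 and 4 is drawn with a defined configuration and the other without, at the place where they differ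

As far as these compounds go, what the R form gives at the chain carbon remains open. So does whether a methoxy or amino group on the same aromatic carbon would fall with compound 1 or with compounds 2 and 4.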